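Swapping a Carbonyl Substituent: Isopropyl to Isopropoxy

The source may report more compounds than this note shows. Statements on the series, on what has been measured and on what is new or still open speak of the compounds shown alone.

Measured compounds and values:
- Compound 1, `O=C(CCCC1CCN(C(=O)c2ccccc2)CC1)c1ncco1`: 77 nM
- Compound 2, `O=C(CCCC1CCN(C(=O)CCC2CCCCC2)CC1)c1ncco1`: 3 nM
- Compound 3, `CC(C)C(=O)N1CCC(CCCC(=O)c2ncco2)CC1`: 250 nM

In an assay on isolated protein for inhibition of Fatty-acid amide hydrolase 1 (Homo sapiens) (a lower number here means a stronger inhibitor, a higher number a weaker inhibitor), compound 3 is the weakest of the three, with its gaps to the others shown by a 3.2-fold higher number from compound 1 to compound 3 (0.51 log units; beyond the scatter) and an 83-fold higher number from compound 2 to compound 3 (1.92 log units; beyond the scatter). Compound 4, `CC(C)OC(=O)N1CCC(CCCC(=O)c2ncco2)CC1`, is not yet measured. It differs from compound 3 by isopropoxy in place of isopropyl on a carbonyl carbon. Going by the values given here, the measured steps all concern how large the group on that carbonyl carbon is; none inserts an oxygen between carbonyl and group, so no step bears directly on this change. The expectation is therefore a step no larger than the scatter, no change at the digits printed from compound 3 to compound 4 (within the scatter). Compound 4 is estimated at 250 nM in this assay, within 60 nM to 1000 nM.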

Compound 4, half-maximal inhibitory concentration: 4 nM
The estimate for compound 4 lay 63-fold (1.80 log units) above the measured number; the whole stated range lies above it.
By their numbers in this assay, from the lowest: compounds 2 and 4 (each within the scatter of the next); then compound 1; then compound 3.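

In this assay, the change from isopropyl to isopropoxy on this carbonyl carbon brings a large gain (a 63-fold lower number from compound 3 to compound 4 (1.80 log units; beyond the scatter)), so what matters at this position is not only how big the group is. Isopropoxy also matches 2-cyclohexylethyl (a 1.3-fold higher number from compound 2 to compound 4 (0.12 log units; within the scatter)) and clearly beats phenyl (a 19-fold lower number from compound 1 to compound 4 (1.28 log units; beyond the scatter)). Nothing measured here explains why the oxygen-bearing group does so well. Still open, from the compounds shown here alone, is how isopropylamino, with nitrogen in place of that oxygen, would compare. Going by these compounds, a longer chain on the oxygen, such as butoxy, is equally open.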